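From (Methylsulfonyl)oxy to Piperazin-1-yl on a Weakly Cytotoxic Core

The compounds below may be only part of what the source reports. "The series", "measured", "known", "first", "only" and "open" are said of these compounds alone.

Measured compounds:
compound 1, `CS(=O)(=O)Oc1c(C(=O)NCc2ccc(F)cc2)nc(Br)c2cccnc12`: > 20000 nM
compound 2, `CS(=O)(=O)NCCCN(c1nc(C(=O)NCc2ccc(F)cc2)c(O)c2ncccc12)S(C)(=O)=O`: 7000 nM
compound 3, `O=C(NCc1ccc(F)cc1)c1nc(NCCO)c2cccnc2c1O`: "not determined" (no result reported)

The read-out here is a functional assay on HCT-116 cells (Homo sapiens) for cytotoxicity, read by MTT assay, with a stated time of 72 h; on this read-out higher numbers stand for weaker inhibition and lower numbers for stronger inhibition. In this assay compound 1 gives > 20000 nM, which is a limit of the assay and not a number. Compound 2 gives 7000 nM. For compound 3 the outcome is "not determined" (no result reported). Compound 1 therefore stands at the limit of > 20000 nM in this assay, at which 1 of the 3 values shown sits, so its true potency is known only as a boundary and cannot be compared in size with anything else shown.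

Compound 4, `O=C(NCc1ccc(F)cc1)c1nc(Br)c2cccnc2c1N1CCNCC1`, differs from compound 1 in one place: piperazin-1-yl in place of (methylsulfonyl)oxy on an aromatic carbon. Among the compounds with values here, no step between two measured compounds covers this exchange, so there is no measured precedent for its size or direction. What is known is that compound 2, which carries a different group on the shared core, gives 7000 nM, a real number rather than a limit. On that basis compound 4 is expected to fall at 9000 nM, with a range from 2500 nM to 40000 nM. The expected step is an at least 2.2-fold lower number from compound 1 to compound 4 (0.34 log units; beyond the scatter), a modest move toward stronger inhibition, with a real chance that only a limit is reported again.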

Compound 4, half-maximal inhibitory concentration: > 10000 nM
Compound 4 gave a limit, no number; the forecaster's own chance of this, stated with the estimate: 35%; middle value at least 1.1-fold (0.04 log units) from the limit.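

Compound 4 gives > 10000 nM, which is a limit and not a number. Compound 1 also stands at a limit, so the step between compound 1 and compound 4 cannot be read. Still open, as far as these compounds go, is whether piperazin-1-yl in place of (methylsulfonyl)oxy changes the cytotoxicity at all, and by how much.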